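The source may report more compounds than this note shows. Statements on the series, on what has been measured and on what is new or still open speak of the compounds shown alone.

Compound 1 `CCN(CC)S(=O)(=O)c1ccc(S(=O)(=O)N2CCC[C@@H](C(=O)N(C)C(C)C)C2)cc1`: in a functional assay on MIA PaCa-2 cells (Homo sapiens) for inhibition, read by MTT assay, with a stated time of 3 days (on this read-out higher numbers stand for weaker inhibition and lower numbers for stronger inhibition), compound 1 gives > 10000 nM, a limit of the assay.
Compound 2 `CCN1CC(NC(=O)[C@@H]2CCCN(S(=O)(=O)c3ccc(S(=O)(=O)N(CC)CC)cc3)C2)C1`: in this assay compound 2 gives > 10000 nM, a limit.
Compound 3 `CCN(CC)S(=O)(=O)c1ccc(S(=O)(=O)N2CCC[C@@H](C(=O)NC3COC3)C2)cc1`: in this assay compound 3 gives > 10000 nM, a limit.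

Going by the values given here, compound 3 thus stands at the limit, and every value so far sits there too (the limit of > 10000 nM in this assay, at which 3 of the 3 values shown sit). The next compound, compound 4 `CCN(CC)S(=O)(=O)c1ccc(S(=O)(=O)N2CCC[C@@H](C(=O)NC)C2)cc1`, differs from compound 3 only at the amide nitrogen: methyl in place of oxetan-3-yl on an amide-type nitrogen. The measured steps at that nitrogen, a step that the two limits leave unreadable from compound 2 to compound 3, and at the carbonyl carbon, a step that the two limits leave unreadable from compound 1 to compound 2 and a step that the two limits leave unreadable from compound 1 to compound 3, are all unreadable from limit to limit, so no direction or size can be taken from them. Compound 4 is expected to remain at the limit in this assay, which as a step means a step that the limit leaves unreadable from compound 3 to compound 4. The estimate for compound 4 is 15000 nM, within 5000 nM to 50000 nM.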

Compound 4, half-maximal inhibitory concentration: > 10000 nM
Compound 4 ended at the assay's limit; the forecaster's own chance of this, stated with the estimate: 85%; the middle value does not contradict the limit.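

No new step can be read among compound 1, compound 2, compound 3 and compound 4, since all four stand at one limit: the limit of > 10000 nM in this assay, at which 4 of the 4 values shown sit. The compounds shown leave open whether any amide substituent on the shared core gives a measurable value in this assay.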